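The source may report more compounds than this note shows. Statements on the series, on what has been measured and on what is new or still open speak of the compounds shown alone.

Measured so far in a functional assay on MCF7 cells (Homo sapiens) for inhibition, read by MTT assay, with a stated time of 3 days (a higher number here means a weaker inhibitor, a lower number a stronger inhibitor), are two compounds:
- compound 1 `C=CCOc1cc(/C=C\c2cc(OC)c(OC)c(OC)c2)ccc1OC` with 12000 nM 
- compound 2 `COCOc1ccccc1/C=C/CCCOc1cc(/C=C\c2cc(OC)c(OC)c(OC)c2)ccc1OC` with 4400 nM 

Compound 2 holds the lower of these two numbers, and its gap to compound 1 lies beyond the scatter. Compound 3 (`COc1ccc(/C=C\c2cc(OC)c(OC)c(OC)c2)cc1OCCC/C=C/c1ccc(Br)cc1`) has not yet been measured. It differs from compound 2 by 4-bromophenyl in place of 2-(methoxymethoxy)phenyl on a double-bonded chain carbon bound to a double-bonded chain carbon. Within the data shown here, no measured pair shows this exchange, and the data give no direction for it. The expectation in this assay is therefore a step no larger than the scatter, with no firm direction. The estimated move is a 1.1-fold lower number from compound 2 to compound 3 (0.04 log units; within the scatter) on that reading. For compound 3 the expected value is 4000 nM (estimated range 1300 nM to 13000 nM).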

Compound 3, half-maximal inhibitory concentration: 37000 nM
The estimate for compound 3 lay 9.3-fold (0.97 log units) below the measured number; measured number above the stated range.
By their numbers in this assay, from the lowest: compound 2; then compound 1; then compound 3.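

In this assay, the aryl group on a double-bonded chain carbon bound to a double-bonded chain carbon clearly matters: 4-bromophenyl in place of 2-(methoxymethoxy)phenyl gives an 8.4-fold higher number from compound 2 to compound 3 (0.92 log units; beyond the scatter) in this series. The chain with an aryl end does not by itself lower the number, since compound 2 lies below compound 1 while the exchange on the saturated chain carbon bound to an oxygen on an aromatic ring gives a 3.1-fold higher number from compound 1 to compound 3 (0.49 log units; beyond the scatter) for the bromine-bearing group. Nothing available bears on the reason for either step.

This exchange changes both the ring substituent and its place, so the contribution of each remains unresolved. Also open, from the compounds shown here alone, is how an unsubstituted phenyl, or a hydroxy or amino group on that ring, would read against compound 2 and compound 3.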